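Swapping a pyridine for a phenyl on a shared core

The source may hold more compounds than are shown below. What is called first, only, known or untested is meant among the compounds shown, and "the series" means these compounds.

Compound 1 `Oc1cccc(-c2cc(-c3ccccn3)nc(-c3ccccc3Cl)c2)c1` stands at "not determined" (no result reported) in an ADME assay on HEK293 cells (Homo sapiens) for cytotoxicity, read by CCK-8 assay and cell counting, with a stated time of 2 days (a higher number here means a weaker inhibitor, a lower number a stronger inhibitor), so it has no number there. Compound 3 `Oc1ccc(-c2cc(-c3ccc(Cl)cc3)nc(-c3ccccn3)c2)cc1` gives 27200 nM there, and compound 2 `Oc1ccc(-c2cc(-c3ccccc3)nc(-c3ccc(Cl)cc3)c2)cc1` gives 4810 nM. The step of a 5.7-fold lower number from compound 3 to compound 2 (0.75 log units; beyond the scatter) is the change (phenyl in place of pyridin-2-yl on an aromatic carbon). Compound 4 `Oc1cccc(-c2cc(-c3ccccc3)nc(-c3ccccc3Cl)c2)c1` arises from compound 1 by phenyl in place of pyridin-2-yl on an aromatic carbon, the same kind of change, not the same: the place differs in what stands around it, meta to a 2-chlorophenyl group and a 3-hydroxyphenyl group rather than to a 4-chlorophenyl group and a 4-hydroxyphenyl group. The difference between the cores of compound 1 and compound 3 is not broken down here. Since compound 1 has no number, the expectation rests on compound 2 with 4810 nM. Compound 4 is expected to give about 6000 nM in this assay, between 2000 nM and 20000 nM.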

Compound 4, half-maximal inhibitory concentration: 1760 nM
Beside the measured number, compound 4's estimate is 3.4-fold (0.53 log units) above it; measured number below the stated range.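

Going by these compounds alone, compound 1 has no number in this assay, so no step from compound 1 to compound 4 can be read. On these data alone, whether this swap on the core of compound 1 would match a 5.7-fold lower number from compound 3 to compound 2 (0.75 log units; beyond the scatter) stays open. No other measurement shown helps explain the value of compound 4.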